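This account rests on a few compounds, and the source may have more. Where it says the series, first, only, none or still open, it means among the compounds named here.

Measured so far in a physicochemical assay for metabolic stability, read by HPLC; a lower number here means that the compound disappears faster, a higher number that the compound lasts longer:
compound 1, `Cc1cn([C@H]2C[C@H](N=[N+]=[N-])[C@@H](COP(=O)(O)Oc3cccnc3)O2)c(=O)[nH]c1=O`: 3.88 h
compound 2, `Cc1cn([C@H]2C[C@H](N=[N+]=[N-])[C@@H](COP(=O)(O)Oc3ccc(Cl)cc3)O2)c(=O)[nH]c1=O`: 5.5 h

Compound 2 holds the higher of the two numbers, yet the step of a 1.4-fold higher number from compound 1 to compound 2 (0.15 log units; within the scatter) sits within the scatter, so the two compounds are not separated by this assay. Compound 3, `Cc1cn([C@H]2C[C@H](N=[N+]=[N-])[C@@H](COP(=O)(O)Oc3cncc(Cl)c3)O2)c(=O)[nH]c1=O`, has not yet been measured. It differs from compound 2 by 5-chloropyridin-3-yl in place of 4-chlorophenyl on an oxygen. Among the compounds with values here, the only measured step that bears on this change is the one from compound 1 to compound 2, which exchanged pyridin-3-yl for 4-chlorophenyl on the same oxygen, and that step stayed within the scatter. Within the data shown here, compound 3 combines the pyridine ring of compound 1 with the chlorine of compound 2, and the single step on hand gives no ground to expect a move beyond the scatter in either direction. The step of a 1.2-fold lower number from compound 2 to compound 3 (0.08 log units; within the scatter) is therefore expected to remain within the scatter. For compound 3 the estimated half-life in this assay is 4.6 h, with a range from 3 h to 7 h.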

Compound 3, half-life: 7.27 h
Beside the measured number, compound 3's estimate is 1.6-fold (0.20 log units) below it; measured number above the stated range.
By their numbers in this assay, from the lowest: compounds 1, 2 and 3 (each within the scatter of the next).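

The exchange of 4-chlorophenyl for 5-chloropyridin-3-yl on the oxygen bonded to phosphorus, read in this assay, gives a 1.3-fold higher number from compound 2 to compound 3 (0.12 log units; within the scatter), so with chlorine present on both rings, a ring of carbon only and a ring with one hetero atom are not separated at this position. The series now also holds a clean test of the chlorine alone, chloro in place of hydrogen on an aromatic carbon, and that change gives a 1.9-fold higher number from compound 1 to compound 3 (0.27 log units; within the scatter), which also leaves the pair unseparated. Neither step has any supporting measurement that would explain it, so the notes offer no account of either.

Still open, going by these compounds, is whether any group on this ring can produce a step beyond the scatter in this assay, for instance an amine, a carboxylic acid or a methoxy group in place of the chlorine. Also open, on these data alone, is how an unsubstituted phenyl would read against the 4-chlorophenyl, and whether a naphthyl group or an ethyl chain in place of the whole aromatic ring on this oxygen would change the half-life by more than these three compounds do.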